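Carbamate chain lengthening in a small cytotoxicity series

The compounds below may be only part of what the source reports. "The series", "measured", "known", "first", "only" and "open" are said of these compounds alone.

Within the data shown here, compound 1 `C=CCOC(=O)Nc1ccc([Se]C#N)cc1` stands at the higher of the two numbers measured so far: in an ADME assay on BEAS-2B cells (Homo sapiens) for cytotoxicity, read by MTT assay, with a stated time of 72 h (on this read-out higher numbers stand for weaker inhibition of growth and lower numbers for stronger inhibition of growth), compound 1 gives 47400 nM. Among the measured compounds shown here, the only other measured compound, compound 2 `O=C(Nc1ccc([Se][Se]c2ccc(NC(=O)Oc3ccccc3)cc2)cc1)Oc1ccccc1`, gives in this assay 8600 nM, a lower number by a margin beyond the scatter.

Compound 3 `CCCCCCOC(=O)Nc1ccc([Se]C#N)cc1` differs from compound 1 in one place: pentyl in place of vinyl on a saturated chain carbon bound to an oxygen next to a carbonyl group. For the measured compounds named here, no measured pair shows a step of this kind, so the expectation is loose. The expected step of a 1.6-fold lower number from compound 1 to compound 3 (0.20 log units; within the scatter) is small, toward a somewhat lower number but possibly within the scatter. Compound 3 is estimated at 30000 nM, between 12000 nM and 75000 nM.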

Compound 3, concentration for total growth inhibition: 35900 nM
Beside the measured number, compound 3's estimate is 1.2-fold (0.08 log units) below it, within the range that was stated.
By their numbers in this assay, from the lowest: compound 2; then compounds 3 and 1 (each within the scatter of the next).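

In this assay pentyl in place of vinyl on a saturated chain carbon bound to an oxygen next to a carbonyl group gives a 1.3-fold lower number from compound 1 to compound 3 (0.12 log units; within the scatter) at this first reading of the position. The allyl to hexyl change, which also removes the double bond outside aromatic rings, thus stays inside the scatter here. Nothing measured on these compounds accounts for this result.

Still open, from the compounds shown here alone, is whether a longer chain, or an amine or carboxylic acid at the end of the chain, would give a step beyond the scatter. A single step also leaves the trend along the chain unresolved.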